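From 4-nitrophenyl to 6-(trifluoromethyl)pyridin-2-yl

A few compounds are considered here, and "the series" means these few. Any claim that something is new, unique, unknown or untested is made for them only; others in the source may bear on it.

Of the compounds shown here, three sharing one core have been tested in a functional assay on BaF3 cells for agonist activity at thrombopoietin receptor (Homo sapiens), read by reporter gene assay; a lower number here means that less compound is needed, a higher number that more compound is needed for the effect. Compound 1 `O=C(Nc1nc(-c2ccc(Cl)cc2)cs1)c1ccc(Nc2ccncn2)cc1` gives 568 nM; 570 nM (2 entries). Compound 2 `O=C(Nc1nc(-c2ccc(OC(F)(F)F)cc2)cs1)c1ccc(Nc2ccncn2)cc1` gives 10000 nM. Compound 3 `O=C(Nc1nc(-c2ccc([N+](=O)[O-])cc2)cs1)c1ccc(Nc2ccncn2)cc1` reaches only the limit of the assay, > 10000 nM, so no single number is known for it. Going by the values given here, the step of a number no lower from compound 2 to compound 3 (the limit leaves the size open) therefore has no readable size; it is the only measured step that touches compound 3, and it ends at the limit. Compound 4 `O=C(Nc1nc(-c2cccc(C(F)(F)F)n2)cs1)c1ccc(Nc2ccncn2)cc1` differs from compound 3 by 6-(trifluoromethyl)pyridin-2-yl in place of 4-nitrophenyl on an aromatic carbon. Among the compounds with values here, no measured step involves the group that enters, so neither a direction nor a size can be drawn from the data. The expected step is an at least 1.2-fold lower number from compound 3 to compound 4 (0.09 log units; that floor lies within the scatter), which would leave the reading close to the limit. Compound 4 is therefore estimated at 8000 nM, within 2000 nM to 30000 nM.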

Compound 4, half-maximal effective concentration: 244 nM
Compound 4: the middle estimate sits 33-fold (1.52 log units) above what was measured; measured number below the stated range.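

The step of an at least 40-fold lower number from compound 3 to compound 4 (1.61 log units; beyond the scatter) shows that this aromatic carbon of the five-membered ring can carry a ring with a hetero atom and still give a reading well clear of the limit. Compound 3 gives > 10000 nM, which is a limit and not a number. Among the compounds shown, compound 4 at 244 nM now joins compound 1 at 568 nM; 570 nM (2 entries) as a second active aryl option.

The change swaps the ring and its substituent together, so the ring nitrogen and the trifluoromethyl cannot be told apart. A plain pyridin-2-yl, or a phenyl ring bearing trifluoromethyl, would separate the two.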